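The source may report more compounds than this note shows. Statements on the series, on what has been measured and on what is new or still open speak of the compounds shown alone.

In a functional assay on NCI-H292 cells (Homo sapiens) for cytotoxicity, read by MTT assay, with a stated time of 72 h, tested at 10 ug/mL (a lower number here means less inhibition of growth, a higher number more inhibition of growth at the concentration tested), compound 1 (`O=C1NC(=S)/C(=C/c2ccc(Cl)cc2)S1`) gives 41.4%, and compound 2 (`O=C1NC(=S)/C(=C/c2ccc(F)cc2)S1`) gives 38%. For the measured compounds named here, compound 1 therefore stands level with the only other measured member of the series, and neither can be ranked above the other. Compound 3 (`O=C1NC(=S)/C(=C/c2ccc(Cl)cc2Cl)S1`) has not yet been measured. Its difference from compound 1 is chloro in place of hydrogen on an aromatic carbon, ortho to a group of 8 heavy atoms and meta to a chloro group. Going by the values given here, only one measured step offers any guide: a number 3.4 percentage points lower from compound 1 to compound 2 (within the scatter). That step exchanges one halogen for another at an already substituted carbon, whereas compound 3 gains a chloro group at a carbon that carries hydrogen in compound 1. Among the compounds with values here, it bears on the new change only loosely, and the data include no measured step of the same kind. The expected step is therefore small, with no clear direction and nothing beyond the scatter, although the uncertainty is wide. The estimated step is a number 0.6 percentage points higher from compound 1 to compound 3 (within the scatter). For compound 3, the estimated value is 42%, with an expected range from 26% to 60%.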

Compound 3, percent growth inhibition at one concentration: 38.4%
Compound 3: the middle estimate sits 3.6 percentage points above what was measured; measured number inside the range.
By their numbers in this assay, from the lowest: compounds 2, 3 and 1 (each within the scatter of the next).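

In this assay, chloro in place of hydrogen on an aromatic carbon, ortho to a group of 8 heavy atoms and meta to a chloro group, gives a number 3 percentage points lower from compound 1 to compound 3 (within the scatter), so a second chloro group at this carbon leaves the read-out unchanged within the scatter. The earlier step only exchanged one halogen for another at an already substituted carbon, whereas this one adds a heavy atom at a carbon that carries hydrogen, and this position therefore accepts that addition with no loss of growth inhibition beyond the scatter. No available evidence bears on why this change leaves the read-out where it is.

Chloro is the only group shown at this carbon, so it remains open whether a different group there, such as an amine, a methoxy group or a carboxylic acid, would shift growth inhibition beyond the scatter. These readings come from a single concentration in one cell line, so they leave open whether the same flat picture would hold across a full concentration range or in other cells.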